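The source may hold more compounds than are shown below. What is called first, only, known or untested is meant among the compounds shown, and "the series" means these compounds.

Measured so far in an ADME assay on a cell-free system (plasma, Rattus norvegicus); a higher number here means a larger unbound share of the compound, a lower number a smaller unbound share

compound 1 `CCCS(=O)(=O)c1ccc(F)c(C#Cc2cc(Cl)ccc2OCC(=O)O)c1` gives 0.004
compound 2 `CS(=O)(=O)c1ccc(Cl)c(C#Cc2cc(Cl)ccc2OCC(=O)O)c1` gives 0.003

In this assay compound 2, at 0.003, stands within the scatter of compound 1, so the two values cannot be told apart. Compound 3 `CS(=O)(=O)c1ccc(F)c(C#Cc2cc(Cl)ccc2OCC(=O)O)c1` has not yet been measured. It differs from compound 2 by fluoro in place of chloro on an aromatic carbon. Within the data shown here, no measured pair here differs in one place, so nothing gauges this change directly, and no shift beyond the scatter is expected. The expected change is a 1.7-fold higher number from compound 2 to compound 3 (0.22 log units; within the scatter). For compound 3 the estimated value is 0.005, with an expected range from 0.002 to 0.012.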

Compound 3, unbound fraction: 0.011
Beside the measured number, compound 3's estimate is 2.2-fold (0.34 log units) below it; the range from low to high includes it.
By their numbers in this assay, from the lowest: compounds 2 and 1 (each within the scatter of the next); then compound 3.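

In this assay, fluoro in place of chloro on the aromatic carbon para to a methylsulfonyl group gives a 3.7-fold higher number from compound 2 to compound 3 (0.56 log units; beyond the scatter). With the methylsulfonyl group held, this position therefore affects the unbound share. Hydrogen in place of ethyl on the sulfonyl chain gives a 2.8-fold higher number from compound 1 to compound 3 (0.44 log units; beyond the scatter), so the chain end matters as well, and no available measurement explains either step.

Going by these compounds, how bromo or methoxy at that aromatic carbon would compare remains open. So does the effect of an amine or a hydroxyl group on the sulfonyl chain.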